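The source may hold more compounds than are shown below. What is called first, only, known or untested is meant among the compounds shown, and "the series" means these compounds.

The series rests on a shared core to which a thioether and an amine are attached. Compound 1 carries an ethylthio group and a (4-methoxybenzyl)amino group, with the structure `CCSc1nc(NCc2ccc(OC)cc2)c2ncn([C@@H]3O[C@H](CO)[C@@H](O)[C@H]3O)c2n1`. In a functional assay on a cell-free system (Platelet, plasma, Homo sapiens) for inhibition, with stated times of 1 min and 3 min (a lower number here means a stronger inhibitor, a higher number a weaker inhibitor), compound 1 gives "not determined" (no result reported): no single number was reported, so nothing can be said of where it stands. Compound 2, with a butylthio group and a cyclohexylamino group, has the structure `CCCCSc1nc(NC2CCCCC2)c2ncn([C@@H]3O[C@H](CO)[C@@H](O)[C@H]3O)c2n1`, and in this assay compound 2 gives 83000 nM, a weak result on this scale.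

Compound 3 has the structure `CCSc1nc(NCc2ccccc2)c2ncn([C@@H]3O[C@H](CO)[C@@H](O)[C@H]3O)c2n1`. It differs from compound 1 by hydrogen in place of methoxy on an aromatic carbon. Among the measured compounds shown here, no measured pair shows what this change does, so the step from compound 1 to compound 3 cannot be placed on any number; the expectation is for a step within the scatter, with no clear direction. For the measured compounds named here, the only anchor is compound 2, which gives 83000 nM on the same core. On that footing, compound 3 is expected to reach about 50000 nM in this assay, with a likely range from 8000 nM to 300000 nM.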

Compound 3, half-maximal inhibitory concentration: 176000 nM
The estimate for compound 3 lay 3.5-fold (0.55 log units) below the measured number; low and high end bracket the measured number.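

Compound 1 offers no single number, and no step can be read from it to compound 3 at 176000 nM. Nothing available bears on the reason for this result. The compounds shown leave open what exchanging methoxy for hydrogen does in this assay, and how the thioether and amine groups each contribute.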